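Methyl for methoxy on the aryl thiourea, second instance

A few compounds are considered here, and "the series" means these few. Any claim that something is new, unique, unknown or untested is made for them only; others in the source may bear on it.

Compound 1 `CCN(CC)CN1C(=O)/C(=N/NC(=S)Nc2ccc(OC)cc2)c2ccccc21` and compound 2 `CCN(CC)CN1C(=O)/C(=N/NC(=S)Nc2ccc(C)cc2)c2ccccc21` differ only on the aryl thiourea: methyl in place of methoxy on an aromatic carbon. In an ADME assay on MDCK cells (Canis lupus familiaris) for cytotoxicity (on this read-out higher numbers stand for lower toxicity in this test and lower numbers for higher toxicity in this test), compound 1 gives 9200 nM, while compound 2 gives 200 nM; the step is a 46-fold lower number from compound 1 to compound 2 (1.66 log units; beyond the scatter). Compound 3 `CCN(CC)CN1C(=O)/C(=N/NC(=S)Nc2ccc(OC)cc2)c2cc(Cl)ccc21` differs from compound 1 on the shared core, (chloro in place of hydrogen on an aromatic carbon), and in this assay compound 3 gives 11100 nM, so the step of a 1.2-fold higher number from compound 1 to compound 3 (0.08 log units; within the scatter) leaves the read-out where compound 1 stands. Compound 3 thus holds the highest number of the three measured, but its gap to compound 1 is within scatter, so no order between those two can be read.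

Compound 4 `CCN(CC)CN1C(=O)/C(=N/NC(=S)Nc2ccc(C)cc2)c2cc(Cl)ccc21` joins the core of compound 3 to the aryl group of compound 2; its difference from compound 3 is methyl in place of methoxy on an aromatic carbon. The place reads word for word as for the change from compound 1 to compound 2, so it is the same change, made on the core of compound 3 rather than that of compound 1.

For compound 4 in this assay the expected step is a 44-fold lower number from compound 3 to compound 4 (1.65 log units; beyond the scatter), because the earlier instance a 46-fold lower number from compound 1 to compound 2 (1.66 log units; beyond the scatter) was large and the core change a 1.2-fold higher number from compound 1 to compound 3 (0.08 log units; within the scatter) stayed within scatter, leaving no sign that the chloro-bearing core would answer differently. Compound 4 is accordingly estimated at 250 nM, expected between 80 nM and 800 nM. Among the measured compounds shown here, only one prior instance of the change exists, so the range is kept wide.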

Compound 4, half-maximal cytotoxic concentration: 11300 nM
Compound 4: middle estimate off by 45-fold (1.66 log units), on the low side; measured number above the stated range.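

In this assay, methyl in place of methoxy on the chloro-bearing core gives a 1.0-fold higher number from compound 3 to compound 4 (0.01 log units; within the scatter), so the large step on the core of compound 1 does not carry over to this core: the same change on two cores in this assay, a 46-fold lower number (1.66 log units; beyond the scatter) from compound 1 to compound 2 and a 1.0-fold higher number (0.01 log units; within the scatter) from compound 3 to compound 4, 47-fold (1.67 log units) apart, beyond the scatter of two such steps. Read the other way, chloro in place of hydrogen gives a 57-fold higher number from compound 2 to compound 4 (1.75 log units; beyond the scatter) with the 4-methylphenyl group, while with the 4-methoxyphenyl group it stayed within scatter, so the two changes cannot be treated as independent in this series: the same change on two cores in this assay, a 1.2-fold higher number (0.08 log units; within the scatter) from compound 1 to compound 3 and a 57-fold higher number (1.75 log units; beyond the scatter) from compound 2 to compound 4, 47-fold (1.67 log units) apart, beyond the scatter of two such steps. Among the compounds shown here, the break rests on compound 2, the one compound of the four with a large step to each of its one-place neighbours, and these compounds show neither why it stands apart nor which of the two outcomes a further core would follow.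

Open, as far as these compounds go, is whether the same dependence on the core appears with a different group at this place on the aryl ring, such as ethyl, fluoro or trifluoromethyl. Also open, from the compounds shown here alone, is whether bromo or methoxy in place of the chloro on the shared core would side with compound 2 or with compound 4 once paired with the 4-methylphenyl group.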